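The compounds below may be only part of what the source reports. "The series", "measured", "known", "first", "only" and "open" are said of these compounds alone.

Measured in a functional assay on HUVEC cells (Homo sapiens) for cytotoxicity; a lower number here means that less compound is needed, a higher number that more compound is needed for the effect:
- compound 1 `COC1=C(C)C(=O)/C(=C(O)/C=C/c2ccc(C)cc2)C(=O)C1(C)C`: 2.4 ug/mL
- compound 2 `COC1=C(C)C(=O)/C(=C(O)/C=C/c2cc(C)cc(C)c2)C(=O)C1(C)C`: 2.5 ug/mL

Only these two numbers are available, and compound 2, at 2.5 ug/mL, cannot be separated from compound 1: the measured step is a 1.0-fold higher number from compound 1 to compound 2 (0.02 log units; within the scatter). The next compound, compound 3 `COC1=C(C)C(=O)/C(=C(O)/C=C/c2ccco2)C(=O)C1(C)C`, changes the same place on the shared core: furan-2-yl in place of 3,5-dimethylphenyl on a double-bonded chain carbon bound to a double-bonded chain carbon. In words, furan-2-yl stands in place of 3,5-dimethylphenyl on a double-bonded chain carbon bound to a double-bonded chain carbon.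

Among the measured compounds shown here, one measured step bears on this change, and only indirectly. For the measured compounds named here, it exchanged 4-methylphenyl for 3,5-dimethylphenyl at this place, and no measured compound carries furan-2-yl. With so little evidence, no direction can be argued in this assay, and the expectation is for no change beyond the scatter, because a 1.0-fold higher number from compound 1 to compound 2 (0.02 log units; within the scatter) is all that has been seen at this place. The expected step is a 1.1-fold higher number from compound 2 to compound 3 (0.05 log units; within the scatter), with wide uncertainty. The estimate for compound 3 is 2.8 ug/mL, with an expected range of 1 ug/mL to 8 ug/mL.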

Compound 3, concentration for half-maximal effect: 2.4 ug/mL
Estimate against measurement, compound 3: 1.2-fold (0.07 log units) above; low and high end bracket the measured number.
By their numbers in this assay, from the lowest: compounds 1, 3 and 2 (each within the scatter of the next).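

In this assay, the exchange at this place now reaches beyond moving methyl groups around a phenyl ring: furan-2-yl in place of 3,5-dimethylphenyl gives a 1.0-fold lower number from compound 2 to compound 3 (0.02 log units; within the scatter), and furan-2-yl in place of 4-methylphenyl gives no change at the digits printed from compound 1 to compound 3 (within the scatter). The earlier pair had shown only that a second methyl group and a different substitution pattern on the same six-membered carbon ring leave the number within the scatter; these steps show the same for a change to a smaller, five-membered aromatic ring carrying a ring oxygen and a hydrogen-bond acceptor. Nothing available explains this flat result, and no supporting data bear on it.

From the compounds shown here alone, all three compounds carry an aromatic ring at this place, and every step among them lies within the scatter, so it remains open whether any change here can move the number in this assay at all. A carboxylic acid or an amine on the ring, or a longer saturated chain in place of the ring, could test that, and the outcome of such a change cannot be read from these compounds.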